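Acetamido on the piperidine of a benzofuran ether series

The compounds below may be only part of what the source reports. "The series", "measured", "known", "first", "only" and "open" are said of these compounds alone.

Measured so far:
compound 1, `c1ccc2sc(Oc3ccc4cc(CN5CCCCC5)oc4c3)nc2c1`: "not determined" (no result reported) in an assay on isolated protein (blood, strain CD1) for inhibition of leukotriene A-4 hydrolase (Mus musculus), read by immunoassay, with stated times of 15 min and 30 min; on this read-out lower numbers stand for stronger inhibition and higher numbers for weaker inhibition
compound 2, `c1cnc2nc(Oc3ccc4c(CN5CCCCC5)coc4c3)sc2c1`: 21 nM

For the measured compounds named here, compound 2 is the only entry with a number in this assay; compound 1 stands without one, so no step between measured compounds can be read. Compound 3, `CC(=O)NC1CCN(Cc2coc3cc(Oc4nc5ncccc5s4)ccc23)CC1`, carries the change (acetamido in place of hydrogen on a saturated ring carbon), acetamido in place of hydrogen on a saturated ring carbon. Going by the values given here, with no comparable step measured, the expectation rests on compound 2 alone, and the step is expected to stay within the scatter, as a 1.4-fold lower number from compound 2 to compound 3 (0.15 log units; within the scatter). Compound 3 is estimated at 15 nM, between 5 nM and 50 nM.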

Compound 3, half-maximal inhibitory concentration: 17 nM
Compound 3: middle estimate off by 1.1-fold (0.05 log units), on the low side; low and high end bracket the measured number.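

In this assay, acetamido in place of hydrogen on the saturated ring carbon gives a 1.2-fold lower number from compound 2 to compound 3 (0.09 log units; within the scatter), so this position, three ring bonds from the ring nitrogen, takes the group without a shift beyond the scatter. For the compounds shown here, this is the only readable step, since steps to compound 1 cannot be read without a number. Nothing measured here speaks to the reason for this result. As far as these compounds go, whether a free amine, a carboxylic acid or a longer chain on the same carbon would fare alike remains open. So does the role of the amide hydrogen.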